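Furan-3-yl in place of phenyl: compound 3 to compound 4

The source may report more compounds than this note shows. Statements on the series, on what has been measured and on what is new or still open speak of the compounds shown alone.

Measured in a functional assay on HeLa S3 cells (Homo sapiens) for cytotoxicity, read by XTT assay, with a stated time of 3 days; a higher number here means a weaker inhibitor, a lower number a stronger inhibitor:
- compound 1 `OC[C@H]1O[C@@H](n2cc(F)c3c(-c4ccccc4)ncnc32)[C@H](O)[C@@H]1O`: 2600 nM
- compound 2 `OC[C@H]1O[C@@H](n2cc(F)c3c(-c4nccs4)ncnc32)[C@H](O)[C@@H]1O`: 3100 nM
- compound 3 `OC[C@H]1O[C@@H](n2cc(Cl)c3c(-c4ccccc4)ncnc32)[C@H](O)[C@@H]1O`: 420 nM

Compound 3 gives the lowest number of the three, with both gaps beyond the scatter. Compound 4 `OC[C@H]1O[C@@H](n2cc(Cl)c3c(-c4ccoc4)ncnc32)[C@H](O)[C@@H]1O` has furan-3-yl in place of phenyl on an aromatic carbon. The nearest measured precedent is a ring swap on the same carbon, a 1.2-fold higher number from compound 1 to compound 2 (0.08 log units; within the scatter), which carries fluoro rather than chloro. The halogen step, a 6.2-fold lower number from compound 1 to compound 3 (0.79 log units; beyond the scatter), is not repeated here, as chloro stays. On this single precedent, no step beyond the scatter is expected in this assay. The estimated change is a 1.4-fold lower number from compound 3 to compound 4 (0.15 log units; within the scatter). For compound 4 the estimated value is 300 nM, with an expected range of 80 nM to 1100 nM.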

Compound 4, half-maximal inhibitory concentration: 2700 nM
The estimate for compound 4 lay 9.0-fold (0.95 log units) below the measured number; measured number above the stated range.
By their numbers in this assay, from the lowest: compound 3; then compounds 1, 4 and 2 (each within the scatter of the next).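

In this assay a ring swap on this aromatic carbon is not always silent: furan-3-yl in place of phenyl gives a 6.4-fold higher number from compound 3 to compound 4 (0.81 log units; beyond the scatter) and so stands beyond the scatter. With fluoro on the core, 1,3-thiazol-2-yl in place of phenyl gave only a 1.2-fold higher number from compound 1 to compound 2 (0.08 log units; within the scatter) and stayed within it. No measurement available here accounts for the difference between these swaps.

Going by these compounds, the two swaps differ in both ring and halogen, so it remains open whether the furan-3-yl loss depends on chloro. Also open, on these data alone, is how an amine or a short alkyl chain would read on this carbon.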